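Phenyl in place of the substituted aryl: compound 4

The compounds below may be only part of what the source reports. "The series", "measured", "known", "first", "only" and "open" are said of these compounds alone.

Within the data shown here, in a functional assay on MCF7 cells (Homo sapiens) for cytotoxicity, read by MTT assay, with a stated time of 24 h (on this read-out lower numbers stand for stronger inhibition and higher numbers for weaker inhibition), the series so far sits at a single level. Compound 1 (`COc1ccc(NC(=O)Nc2cccc3c(Oc4ccc([N+](=O)[O-])cc4)cccc23)cc1`) gives 953 nM, compound 2 (`CC(=O)Nc1ccc(Oc2cccc3c(NC(=O)Nc4ccccc4)cccc23)cc1`) gives 953 nM, and compound 3 (`O=C(Nc1ccc(Cl)c(C(F)(F)F)c1)Nc1cccc2c(Oc3ccc([N+](=O)[O-])cc3)cccc12`) gives 953 nM, so compound 3 stands level with both.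

Compound 4 (`O=C(Nc1ccccc1)Nc1cccc2c(Oc3ccc([N+](=O)[O-])cc3)cccc12`) has not yet been measured. Its difference from compound 3 is phenyl in place of 4-chloro-3-(trifluoromethyl)phenyl on an amide-type nitrogen, which amounts to phenyl in place of 4-chloro-3-(trifluoromethyl)phenyl on an amide-type nitrogen.

Among the measured compounds shown here, one measured step bears directly on that place: no change at the digits printed from compound 1 to compound 3 (within the scatter), with 4-chloro-3-(trifluoromethyl)phenyl in place of 4-methoxyphenyl on the same nitrogen. Though it differs from compound 4 elsewhere, compound 2 also carries phenyl on an amide-type nitrogen and gives 953 nM. Neither measures the phenyl change itself, and a single step is thin evidence. On the evidence of compound 3 at 953 nM and compound 1 at 953 nM, no step beyond the scatter is expected in this assay, in either direction. The expected step is no change at the digits printed from compound 3 to compound 4 (within the scatter), an estimate within the scatter. For compound 4 the estimated value is 953 nM, with an expected range of 450 nM to 2000 nM.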

Compound 4, half-maximal inhibitory concentration: 953 nM
For compound 4 middle estimate and measured number coincide at the digits printed; low and high end bracket the measured number.
By their numbers in this assay, from the lowest: compounds 1, 2, 3 and 4 (each within the scatter of the next).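

Phenyl in place of 4-chloro-3-(trifluoromethyl)phenyl on the amide-type nitrogen gives no change at the digits printed from compound 3 to compound 4 (within the scatter) in this assay, the first direct reading of the bare phenyl at this position with the nitro group held fixed. Hydrogen in place of methoxy on an aromatic carbon gives no change at the digits printed from compound 1 to compound 4 (within the scatter), so the phenyl, 4-methoxyphenyl and 4-chloro-3-(trifluoromethyl)phenyl groups now all stand level on this nitrogen, and neither the loss of the methoxy group nor the smaller group entering in place of the 11-heavy-atom aryl shows any effect here. Nitro in place of acetamido on an aromatic carbon gives no change at the digits printed from compound 2 to compound 4 (within the scatter), which extends the same flat picture to a second place in the molecule, with phenyl held on the nitrogen.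

Going by these compounds, it remains open whether any group on this nitrogen can shift the value, such as a longer alkyl chain in place of the aryl, or an amine or a carboxylic acid on the phenyl ring. On these data alone, it is equally open whether an amine in place of the nitro group would separate from this level, and the data on hand give no reason for the flat response.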